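Cyclohexyl for Dichlorophenyl: Expected Effect on Cytotoxicity

The source may report more compounds than this note shows. Statements on the series, on what has been measured and on what is new or still open speak of the compounds shown alone.

Compound 1 `CCC1(Cc2ccccc2)OS(=O)(=O)C=C1OCC(=O)OC` gives in an ADME assay on HEL cells (Homo sapiens) for cytotoxicity, with a stated time of 3 days (on this read-out higher numbers stand for lower toxicity in this test and lower numbers for higher toxicity in this test), a value of > 200000 nM, which is a limit of the assay and not a number.
Compound 2 `CCC1(Cc2ccccc2)OS(=O)(=O)C=C1OCc1ccc(Cl)c(Cl)c1` gives 36700 nM in this assay.
Compound 3 `CCC1(Cc2ccccc2)OS(=O)(=O)C=C1NCc1ccccc1` gives 92000 nM in this assay.

Compound 2 holds the lowest of the two numbers shown; compound 3 sits higher, beyond the scatter, and compound 1 shows only the limit (the limit of > 200000 nM in this assay, at which 1 of the 3 values shown sits). Compound 4 `CCC1(Cc2ccccc2)OS(=O)(=O)C=C1OCC1CCCCC1` is not yet measured. It differs from compound 2 by cyclohexyl in place of 3,4-dichlorophenyl on a saturated chain carbon bound to an oxygen on an unsaturated carbon. The step that bears on this same place is an at least 5.4-fold lower number from compound 1 to compound 2 (0.73 log units; beyond the scatter), where a methoxycarbonyl gave way to the 3,4-dichlorophenyl. The step of an at least 2.1-fold lower number from compound 1 to compound 3 (0.33 log units; beyond the scatter) changes a different place and so speaks less directly. Since the new group is again a six-membered ring of carbon, the number for compound 4 is expected to stay nearer compound 2 than compound 1, with a small rise that may not exceed the scatter, as a 1.6-fold higher number from compound 2 to compound 4 (0.21 log units; within the scatter). Compound 4 is therefore estimated at 60000 nM, between 20000 nM and 180000 nM.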

Compound 4, half-maximal cytotoxic concentration: > 200000 nM
Compound 4: a limit, no number (the forecaster's own chance of this, stated with the estimate: 20%); middle value at least 3.3-fold (0.52 log units) away from the limit.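

In this assay, a six-membered ring of carbon at this place is not enough to keep the low number of compound 2: cyclohexyl in place of 3,4-dichlorophenyl gives an at least 5.4-fold higher number from compound 2 to compound 4 (0.73 log units; beyond the scatter). Compound 4 gives > 200000 nM, which is a limit of the assay and not a number, and this limit is now shared: the limit of > 200000 nM in this assay, at which 2 of the 4 values shown sit. Cyclohexylmethoxy in place of benzylamino gives an at least 2.1-fold higher number from compound 3 to compound 4 (0.33 log units; beyond the scatter), while the step between compound 1 and compound 4 joins two limits and cannot be read.

The compounds shown do not separate the part played by the chlorine atoms from that of the aromatic ring, and a plain phenyl at this place would address that question. Going by these compounds, how a pyridyl or a longer chain would read here also stays open.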